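The source may hold more compounds than are shown below. What is called first, only, known or untested is meant among the compounds shown, and "the series" means these compounds.

Values in an ADME assay on MT4 cells (Homo sapiens) for cytotoxicity, read by MTT assay, with a stated time of 5 days; on this read-out lower numbers stand for higher toxicity in this test and higher numbers for lower toxicity in this test:
- compound 1 `Cc1cc(/C=C/C#N)cc(C)c1Oc1nc(Nc2ccc(CN3CCNCC3)cc2)nc2sccc12`: 4030 nM
- compound 2 `Cc1cc(/C=C/C#N)cc(C)c1Oc1nc(Nc2ccc(N3CCN(S(N)(=O)=O)CC3)cc2)nc2sccc12`: > 222000 nM
- compound 3 `Cc1cc(/C=C/C#N)cc(C)c1Oc1nc(Nc2ccc(N3CCCC(N)C3)cc2)nc2sccc12`: 4610 nM

The value of compound 2 is a limit of the assay, not a number.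

Compound 3 stands level with compound 1, with a 1.1-fold higher number from compound 1 to compound 3 (0.06 log units; within the scatter). Against compound 2 the gap is wide, with an at least 48-fold lower number from compound 2 to compound 3 (1.68 log units; beyond the scatter).

Compound 4 `Cc1cc(/C=C/C#N)cc(C)c1Oc1nc(Nc2ccc(CN3CCN(S(N)(=O)=O)CC3)cc2)nc2sccc12` carries (4-sulfamoylpiperazin-1-yl)methyl in place of 3-aminopiperidin-1-yl on an aromatic carbon, para to a large group ((4-sulfamoylpiperazin-1-yl)methyl in place of 3-aminopiperidin-1-yl on an aromatic carbon).

Among the compounds with values here, two measured steps bear on this change, and both are large and both involve the 4-sulfamoylpiperazin-1-yl group of compound 2: an at least 55-fold higher number from compound 1 to compound 2 (1.74 log units; beyond the scatter) and an at least 48-fold lower number from compound 2 to compound 3 (1.68 log units; beyond the scatter). In compound 4 that group returns with the methyl of compound 1, so the match is not exact. Within the data shown here, only three compounds support this reading.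

A large step to a higher number is expected in this assay, and its size is uncertain: a 22-fold higher number from compound 3 to compound 4 (1.34 log units; beyond the scatter). For compound 4 the estimate is 100000 nM, with an expected range of 25000 nM to 300000 nM.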

Compound 4, half-maximal cytotoxic concentration: > 217000 nM
Compound 4 was reported as a limit; the forecaster's own chance of this, stated with the estimate: 45%; middle value at least 2.1-fold (0.33 log units) from the limit.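

In this assay compound 4 gives a limit of the assay, not a number: the limit of > 217000 nM in this assay, at which 1 of the 4 values shown sits.

The high number seen with 4-sulfamoylpiperazin-1-yl in compound 2 now also appears with (4-sulfamoylpiperazin-1-yl)methyl at this aromatic carbon, para to a large group, so it is not confined to the group without the methyl: the exchange for 3-aminopiperidin-1-yl gives an at least 47-fold higher number from compound 3 to compound 4 (1.67 log units; beyond the scatter).

With the (piperazin-1-yl)methyl of compound 1 otherwise kept, sulfamoyl in place of hydrogen on the ring amine nitrogen alone gives an at least 53-fold higher number from compound 1 to compound 4 (1.73 log units; beyond the scatter), which places the large step on that single substitution within this pair.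

The step between compound 2 and compound 4 cannot be read, as both values are limits. Open too, from the compounds shown here alone, is whether sulfamoyl is specifically needed, or whether an acetyl or a methanesulfonyl group on the same ring nitrogen would give a similar number.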